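The compounds below may be only part of what the source reports. "The series", "measured", "known", "first", "only" and "open" are said of these compounds alone.

Of the compounds shown here, three have already been measured, each in an assay on HEK293 cells for agonist activity at transient receptor potential cation channel subfamily M member 8 (Homo sapiens), read by fluorescence and calcium flux, with a stated time of 15 min; a lower number here means that less compound is needed, a higher number that more compound is needed for the effect. Compound 1, with structure `Cc1ccc(OCC(=O)N(Cc2cccs2)c2ccn(C)n2)cc1`, gives 855 nM in this assay. Compound 2, with structure `CCN(Cc1cccs1)C(=O)c1cc2cc(C)ccc2s1`, gives 1600 nM in this assay, a number that lies within the usual scatter of the number for compound 1, so that the two cannot be told apart. Compound 3, with structure `CCCc1ccc(OCC(=O)N(CC)Cc2cccs2)cc1`, gives 1810 nM in this assay, a number that stands beyond the scatter above that of compound 1. Compound 1 therefore has the lowest of the three numbers, although only its separation from compound 3 is large enough to count.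

The account now turns to compound 4, whose structure is `Cc1ccc(OCC(=O)N(Cc2cccs2)C2COC2)cc1` and which has not yet been measured. It differs from compound 1 in one place: oxetan-3-yl in place of 1-methyl-1H-pyrazol-3-yl on an amide-type nitrogen. Among the compounds with values here, no pair of measured compounds differs in only one place, so nothing measured here shows how such a change behaves. Because compound 2 gives 1600 nM and compound 3 gives 1810 nM, the spread across this small set is itself modest. An expected step of a 1.9-fold higher number from compound 1 to compound 4 (0.27 log units; within the scatter) toward a somewhat higher number therefore seems reasonable for compound 4. Compound 4 is thus estimated at 1600 nM in this assay, with an expected range from 500 nM to 5000 nM.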

Compound 4, half-maximal effective concentration: 23000 nM
Beside the measured number, compound 4's estimate is 14-fold (1.16 log units) below it; the measured number lies above the stated range.
By their numbers in this assay, from the lowest: compounds 1, 2 and 3 (each within the scatter of the next, the first and the last beyond it); then compound 4.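

In this assay, within the data shown here, putting oxetan-3-yl in place of 1-methyl-1H-pyrazol-3-yl on the amide-type nitrogen gives a 27-fold higher number from compound 1 to compound 4 (1.43 log units; beyond the scatter), the first step that can be read at a single place, and it shows that this position is far from indifferent to the group it carries. Neither group has a hydrogen-bond donor or a net charge, so the two do not differ in those counts; what differs is that a five-membered aromatic ring with 2 hetero atoms leaves and a smaller, four-membered non-aromatic ring enters. Nothing measured here explains why the number rises so sharply.

The compounds shown do not separate ring size from aromatic character, so it remains open whether a phenyl or a cyclobutyl group on the same nitrogen would stay close to compound 1 or fall near compound 4. As far as these compounds go, it is also open whether the methyl on the pyrazole matters, and the ethyl group on that nitrogen in compound 3 cannot settle the question of open-chain groups, as that compound differs from compound 1 in more than one place.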